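A few compounds are considered here, and "the series" means these few. Any claim that something is new, unique, unknown or untested is made for them only; others in the source may bear on it.

Going by the values given here, in a functional assay on U-373MG ATCC cells (Homo sapiens) for inhibition, read by MTT assay, with a stated time of 72 h (on this read-out lower numbers stand for stronger inhibition and higher numbers for weaker inhibition), compound 3 `CC1(C)CC(NC(=S)Nc2ccccc2)c2cc(Cl)ccc2O1` gives 46000 nM as the highest of the three numbers measured so far. Compound 1 `CC1(C)CC(NC(=S)Nc2ccc(C#N)cc2)c2cc(Cl)ccc2O1` gives 10000 nM and compound 2 `CC1(C)CC(NC(=S)Nc2ccc([N+](=O)[O-])cc2)c2cc(Br)ccc2O1`, which also carries nitro, gives 9000 nM in the same read-out. Both numbers lie lower than that of compound 3 and beyond the scatter.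

Compound 4 `CC1(C)CC(NC(=S)Nc2ccc([N+](=O)[O-])cc2)c2cc(Cl)ccc2O1` differs from compound 3 by nitro in place of hydrogen on an aromatic carbon with nitro in place of hydrogen on an aromatic carbon. Among the compounds with values here, the one measured step bearing on this is a 4.6-fold higher number from compound 1 to compound 3 (0.66 log units; beyond the scatter) for hydrogen in place of cyano, a modest one. Read in reverse, it points to a modest move towards a lower number in this assay for the present change. The expected step is a 4.6-fold lower number from compound 3 to compound 4 (0.66 log units; beyond the scatter) on that reading. Compound 4 is estimated at 10000 nM with an expected range from 5000 nM to 20000 nM in this series.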

Compound 4, half-maximal inhibitory concentration: 3000 nM
Compound 4: the middle estimate sits 3.3-fold (0.52 log units) above what was measured, and the stated range ends above it.
By their numbers in this assay, from the lowest: compound 4; then compounds 2 and 1 (each within the scatter of the next); then compound 3.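

In this assay, nitro on the aromatic carbon para to a large group gives a 15-fold lower number from compound 3 to compound 4 (1.19 log units; beyond the scatter) and remains ahead of the nitrile at that place, with a 3.3-fold lower number from compound 1 to compound 4 (0.52 log units; beyond the scatter), so the identity of the group matters here and not only the loss of hydrogen. The halogen also counts with nitro in place, since chloro in place of bromo gives a 3.0-fold lower number from compound 2 to compound 4 (0.48 log units; beyond the scatter) as a further modest step. No measurement shown accounts for either step.

As far as these compounds go, whether an amine or a carboxylic acid at the same place also lowers the number remains open. So does whether the nitrile and nitro steps would keep their size with bromo in place of chloro.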